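A Second Methoxy Position on the Shared Core

A few compounds are considered here, and "the series" means these few. Any claim that something is new, unique, unknown or untested is made for them only; others in the source may bear on it.

Compound 1 `O=C(/C=C/c1ccc2c(c1)B(O)OC2)c1ccccc1` is the parent of this small set. For the measured compounds named here, in a functional assay on HCT-116 cells (Homo sapiens) for cytotoxicity, read by MTT assay, with a stated time of 48 h (a lower number here means a stronger inhibitor, a higher number a weaker inhibitor), compound 1 gives 6100 nM, the highest of the two numbers measured so far. Going by the values given here, its only measured neighbour, compound 2 `COc1ccccc1C(=O)/C=C/c1ccc2c(c1)B(O)OC2`, gives 5000 nM in this assay; the step of a 1.2-fold lower number from compound 1 to compound 2 (0.09 log units; within the scatter) comes from a methoxy in place of hydrogen on an aromatic carbon, and it lies within the scatter of repeated measurements.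

Compound 3 `COc1cccc(C(=O)/C=C/c2ccc3c(c2)B(O)OC3)c1` has not yet been measured. It differs from compound 1 by methoxy in place of hydrogen on an aromatic carbon. Among the compounds with values here, the one measured step that bears on this change, a 1.2-fold lower number from compound 1 to compound 2 (0.09 log units; within the scatter), is likewise a methoxy added on an aromatic carbon of compound 1, and it did not move the number beyond the scatter. Within the data shown here, no measured step speaks to this particular position of the methoxy. On that basis the expected step of a 1.1-fold lower number from compound 1 to compound 3 (0.04 log units; within the scatter) is small, in no reliable direction, and compound 3 is estimated at 5500 nM in this assay, within a range from 2500 nM to 12000 nM.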

Compound 3, half-maximal inhibitory concentration: 5000 nM
Compound 3: the middle estimate sits 1.1-fold (0.04 log units) above what was measured, within the range that was stated.
By their numbers in this assay, from the lowest: compounds 2, 3 and 1 (each within the scatter of the next).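

With the methoxy meta to a large group, the step from the parent, a 1.2-fold lower number from compound 1 to compound 3 (0.09 log units; within the scatter), stays as small as the one seen earlier, so a second position on this ring also leaves the number within the scatter. In this assay compound 2 gives 5000 nM and compound 3 gives 5000 nM, the same printed value, so these two placements of the methoxy cannot be told apart in this measurement. Nothing in the available data offers an explanation for this flat result.

The compounds shown leave open whether a different group on the same ring, such as an amine, a carboxylic acid or a longer alkoxy chain, would carry the number beyond the scatter in either direction. They also leave open whether a second methoxy on this ring, or a methoxy placed elsewhere on the shared core, would change the number any more than these two single additions do.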